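From compound 3 to compound 4: a substituted phenyl

This account rests on a few compounds, and the source may have more. Where it says the series, first, only, none or still open, it means among the compounds named here.

In an ADME assay on HepG2 cells (Homo sapiens) for cytotoxicity, read by MTT assay, with a stated time of 48 h (on this read-out higher numbers stand for weaker inhibition and lower numbers for stronger inhibition), compound 3 (`O=S(=O)(c1ccc(-c2ccc3ncnc(Nc4ccccc4)c3c2)cc1)N1CCOCC1`) gives > 3000 nM, which is a limit and not a number. Compound 1 (`O=S(=O)(c1cccc(-c2ccc3ncnc(Nc4ccc(OCc5cccc(F)c5)c(Cl)c4)c3c2)c1)N1CCCC1`) gives > 15000 nM, also a limit. Compound 2 (`CS(=O)(=O)c1cccc(-c2ccc3ncnc(Nc4ccc(OCc5cccc(F)c5)c(Cl)c4)c3c2)c1`) gives > 15000 nM, again a limit. Among the compounds with values here, the one measured step, a step that the two limits leave unreadable from compound 1 to compound 2, has no readable size and concerns a different change. Compound 4 (`O=S(=O)(c1ccc(-c2ccc3ncnc(Nc4ccc(O)c(Cl)c4)c3c2)cc1)N1CCOCC1`) has 3-chloro-4-hydroxyphenyl in place of phenyl on a nitrogen on an aromatic ring. No measured step sizes this change, so this assay is expected to show only weak inhibition, with no firm direction. The expected step that the limit leaves unreadable from compound 3 to compound 4 is a rough estimate. Compound 4 is estimated at 8000 nM, within an expected range of 2500 nM to 30000 nM.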

Compound 4, half-maximal inhibitory concentration: > 15000 nM
Compound 4 ended at the assay's limit (the forecaster's own chance of this, stated with the estimate: 65%); at least 1.8-fold (0.27 log units) between middle value and limit.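

Compound 3 and compound 4 both give only limits in this assay, not numbers, so the step between them cannot be read. The compounds shown leave open whether 3-chloro-4-hydroxyphenyl in place of phenyl changes inhibition at all, and in which direction.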